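Removing a nitrile from the core of compound 2

A few compounds are considered here, and "the series" means these few. Any claim that something is new, unique, unknown or untested is made for them only; others in the source may bear on it.

Measured so far:
compound 1 `O=C1c2ccc(Cl)cc2C(C2CC2)N1c1cccnc1`: 161 nM
compound 2 `N#Cc1ccc2c(c1)CN(c1cccnc1)C2=O`: 232 nM
compound 3 `CCC(=O)N[C@@H]1CCCc2c1cncc2N1C(=O)c2ccc(Cl)cc2[C@@H]1CC`: 12 nM

In an assay on cells for inhibition of cytochrome P450 11B2, mitochondrial (Homo sapiens), read by HTRF (on this read-out higher numbers stand for weaker inhibition and lower numbers for stronger inhibition), compound 2 gives the highest of the three numbers; compound 1 sits within the scatter of it, while compound 3 lies well below, beyond the scatter. Compound 4 `O=C1c2ccccc2CN1c1cccnc1` differs from compound 2 in one place: hydrogen in place of cyano on an aromatic carbon. Among the compounds with values here, no measured pair shows this change, so its effect is not known from the data. Within the data shown here, since the cyano is the only group on that ring of compound 2, its removal is expected to cost some potency, a modest step upward in this assay that may still fall within the scatter. Compound 4 is therefore estimated at 500 nM, between 150 nM and 1600 nM, an expected step of a 2.2-fold higher number from compound 2 to compound 4 (0.33 log units; beyond the scatter).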

Compound 4, half-maximal inhibitory concentration: 1120 nM
The estimate for compound 4 lay 2.2-fold (0.35 log units) below the measured number, and the stated range covers the measured number.
By their numbers in this assay, from the lowest: compound 3; then compounds 1 and 2 (each within the scatter of the next); then compound 4.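

Within the data shown here, compound 2 and compound 4 are the first pair to isolate this change, and they show that the group on this aromatic carbon matters: replacing cyano with hydrogen gives a 4.8-fold higher number from compound 2 to compound 4 (0.68 log units; beyond the scatter) in this assay. In this pair, then, the cyano group goes with stronger inhibition than a bare hydrogen.

As far as these compounds go, whether an amine, a methoxy group or a carboxylic acid on the same carbon would match the cyano group remains open. Nothing shown here explains the size of this step.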